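A few compounds are considered here, and "the series" means these few. Any claim that something is new, unique, unknown or untested is made for them only; others in the source may bear on it.

Compound 1 `Cc1ccc(S(=O)(=O)N2CC(c3ccc(Br)cc3)NC2=O)cc1` and compound 2 `O=C1NC(c2ccc(Br)cc2)CN1S(=O)(=O)c1ccc(Cl)cc1` share one core; compound 3 `Cc1ccc(S(=O)(=O)N2C(=O)NCC2c2ccc(Br)cc2)cc1` has the same atoms joined differently, and the difference between the two cores is not broken down here. Compound 4 `O=C1NCC(c2ccc(Br)cc2)N1S(=O)(=O)c1ccc(Cl)cc1` pairs with compound 3 as compound 2 does with compound 1.

In a functional assay on SK-MEL-2 cells (Homo sapiens) for cytotoxicity (a lower number here means a stronger inhibitor, a higher number a weaker inhibitor), compound 1 gives only a limit, > 253000 nM. Compound 2 gives 111000 nM, and compound 3 gives 80000 nM; these two sit within the scatter of each other. The change chloro in place of methyl on an aromatic carbon made the step of an at least 2.2-fold lower number from compound 1 to compound 2 (0.35 log units; beyond the scatter), which rests on the limit of > 253000 nM in this assay, at which 1 of the 3 values shown sits, and so is only a lower bound.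

The change chloro in place of methyl on an aromatic carbon is the same one, at the same place. Compound 4 is expected to move by a 2.0-fold lower number from compound 3 to compound 4 (0.30 log units; within the scatter), a step of similar size to the measured one. Compound 4 is estimated at 40000 nM, between 15000 nM and 100000 nM.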

Compound 4, half-maximal inhibitory concentration: 106000 nM
The estimate for compound 4 lay 2.7-fold (0.42 log units) below the measured number; measured number outside the range, above it.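

Carried from one core to the other in this assay, chloro in place of methyl does not give a matching step: the same change on two cores in this assay, an at least 2.2-fold lower number (0.35 log units; beyond the scatter) from compound 1 to compound 2 and a 1.3-fold higher number (0.12 log units; within the scatter) from compound 3 to compound 4, at least 3.0-fold (0.48 log units) apart, beyond the scatter of two such steps. On the core of compound 3, the change gives a 1.3-fold higher number from compound 3 to compound 4 (0.12 log units; within the scatter), so no effect can be told from the scatter on that core. Compound 1 gives only a limit, > 253000 nM, and a single pair on each core does not show why the two steps part.

Open, from the compounds shown here alone, is whether other groups at the same place, such as methoxy, nitrile, an amine or a carboxylic acid, would also give different steps on the two cores.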